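The source may report more compounds than this note shows. Statements on the series, on what has been measured and on what is new or still open speak of the compounds shown alone.

Measured so far in an ADME assay on Caco-2 cells (Homo sapiens) for cytotoxicity, read by neutral red uptake, with a stated time of 72 h; a higher number here means that more compound is tolerated, a lower number that less compound is tolerated:
compound 1 `COc1cc(NC(C)CCCNC(=O)C2CCC3(CC2)OOC2(OO3)C3CC4CC(C3)CC2C4)c2ncccc2c1-c1ccc(Cl)cc1` — > 50000 nM
compound 2 `COc1cc(NC(C)CCCNC(=O)C2CCC3(CC2)OOC2(OO3)C3CC4CC(C3)CC2C4)c2ncccc2c1-c1ccc(C(F)(F)F)cc1` — > 50000 nM

Compound 1 gives > 50000 nM in this assay, which is a limit of the assay and not a number. Compound 2 gives > 50000 nM in this assay, likewise a limit. Both values sit at the limit of > 50000 nM in this assay, at which 2 of the 2 values shown sit. Among the compounds with values here, the only measured step between these two, a step that the two limits leave unreadable from compound 1 to compound 2, therefore cannot be read in size or direction; it shows only that neither compound reaches a measurable value within the tested range.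

Compound 3 `COc1cc(NC(C)CCCNC(=O)C2CCC3(CC2)OOC2(OO3)C3CC4CC(C3)CC2C4)c2ncccc2c1-c1ccsc1` is the next compound to be measured in this assay. The change from compound 2 is thiophen-3-yl in place of 4-(trifluoromethyl)phenyl on an aromatic carbon. Within the data shown here, no measured step covers this change, and the single step available, a step that the two limits leave unreadable from compound 1 to compound 2, gives no size to build on. What is known is that two compounds of the series sit at the limit of > 50000 nM in this assay, at which 2 of the 2 values shown sit, so the expectation for compound 3 is that it too shows no measurable cytotoxicity, with the estimated step of a number no higher from compound 2 to compound 3 (the limit leaves the size open) being none beyond the scatter. Compound 3 is estimated at 50000 nM, with a range from 20000 nM to 120000 nM.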

Compound 3, half-maximal cytotoxic concentration: > 50000 nM
Compound 3: a limit, no number; the forecaster's own chance of this, stated with the estimate: 80%; the middle value lies on the limit itself.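

The steps linking compound 3 to compound 1 and compound 2 in this assay cannot be read, since all three compounds stand at a limit: the limit of > 50000 nM in this assay, at which 3 of the 3 values shown sit.

The compounds shown leave open at what concentration any of the three becomes cytotoxic, and whether 4-chlorophenyl, 4-(trifluoromethyl)phenyl and thiophen-3-yl differ at all.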